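The source may hold more compounds than are shown below. What is called first, only, known or untested is meant among the compounds shown, and "the series" means these compounds.

In a functional assay, read by fluorescence and spectrophotometry, with a stated time of 1 h (on this read-out lower numbers stand for an effect already at smaller amounts and higher numbers for an effect only at larger amounts of compound), three compounds sharing one core have been measured. Compound 1 `CCCCCCCCCCCCS(=O)(=O)/C=C/c1ccc(O)c(O)c1` gives 8500 nM, compound 2 `CCCCCS(=O)(=O)/C=C/c1ccc(O)c(O)c1` gives 8100 nM, and compound 3 `O=S(=O)(/C=C/c1ccc(O)c(O)c1)CC1CCCCO1` gives 10800 nM. Compound 3 therefore stands level with the other two, as its gaps to both lie within the scatter. Compound 4 `O=S(=O)(/C=C/c1ccc(O)c(O)c1)CC1CCCC1` differs from compound 3 in one place: cyclopentyl in place of oxan-2-yl on a saturated chain carbon bound to a sulfonyl sulfur. This puts cyclopentyl in place of oxan-2-yl on a saturated chain carbon bound to a sulfonyl sulfur.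

For the measured compounds named here, two measured steps bear on this change. The closer one, at the same carbon, has oxan-2-yl in place of butyl and is a 1.3-fold higher number from compound 2 to compound 3 (0.12 log units; within the scatter). The other, with hydrogen in place of heptyl further along the chain, is a 1.0-fold lower number from compound 1 to compound 2 (0.02 log units; within the scatter). Going by the values given here, both lie within the scatter, but no measured compound carries a ring of carbon only at this carbon, so the evidence is indirect. No shift beyond the scatter is expected in this assay. The expected change is a 1.2-fold lower number from compound 3 to compound 4 (0.08 log units; within the scatter). Compound 4 is estimated at 9000 nM, with an expected range of 4500 nM to 18000 nM.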

Compound 4, half-maximal effective concentration: 9400 nM
Compound 4: the middle estimate sits 1.0-fold (0.02 log units) below what was measured; the range from low to high includes it.
By their numbers in this assay, from the lowest: compounds 2, 1, 4 and 3 (each within the scatter of the next).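

In this assay, cyclopentyl in place of oxan-2-yl on a saturated chain carbon bound to a sulfonyl sulfur gives a 1.1-fold lower number from compound 3 to compound 4 (0.06 log units; within the scatter), and cyclopentyl in place of butyl at that same carbon gives a 1.2-fold higher number from compound 2 to compound 4 (0.06 log units; within the scatter). This carbon has now carried an open chain, a six-membered ring with one oxygen and a five-membered ring of carbon only, and neither step involving the ring of carbon only lies beyond the scatter, so removing the ring oxygen shows no measurable effect here. No measurement shown explains why these groups read alike. As far as these compounds go, whether an amine or a carboxylic acid on this carbon would shift the number beyond the scatter stays open. From the compounds shown here alone, the sulfonyl side is the only part that varies here, so the role of the two hydroxyl groups on the shared core also remains unknown.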